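Ester side-chain variation in a glycosidic antiproliferative series

A few compounds are considered here, and "the series" means these few. Any claim that something is new, unique, unknown or untested is made for them only; others in the source may bear on it.

Compound 1, `C/C=C1/[C@H](O[C@@H]2O[C@H](CO)[C@@H](O)[C@H](O)[C@H]2O)OC=C(C(=O)OC)[C@H]1CC(=O)OCCC1CCCCC1`: 2000 nM
Compound 2, `C/C=C1/[C@H](O[C@@H]2O[C@H](COC(C)=O)[C@@H](OC(C)=O)[C@H](OC(C)=O)[C@H]2OC(C)=O)OC=C(C(=O)OC)[C@H]1CC(=O)O`: a limit, > 15000 nM
Compound 3, `C/C=C1/[C@H](O[C@@H]2O[C@H](CO)[C@@H](O)[C@H](O)[C@H]2O)OC=C(C(=O)OC)[C@H]1CC(=O)OCCc1ccc(F)cc1`: a limit, > 20000 nM

In a functional assay on SK-BR-3 cells (Homo sapiens) for antiproliferative activity, read by MTT assay, with a stated time of 72 h (a higher number here means a weaker inhibitor, a lower number a stronger inhibitor), compound 1 gives 2000 nM. For compound 2 only a limit is reported, > 15000 nM, and this is the limit of > 15000 nM in this assay, at which 1 of the 3 values shown sits. For compound 3 only a limit is reported as well, > 20000 nM, which is the limit of > 20000 nM in this assay, at which 1 of the 3 values shown sits. Compound 3 therefore stands at the weak end of the numbers shown, and the one measured step touching it, an at least 10-fold higher number from compound 1 to compound 3 (1.00 log units; beyond the scatter), is the only step of known size in this assay.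

Compound 4, `C/C=C1/[C@H](O[C@@H]2O[C@H](CO)[C@@H](O)[C@H](O)[C@H]2O)OC=C(C(=O)OC)[C@H]1CC(=O)OCCc1ccc([N+](=O)[O-])cc1`, differs from compound 3 in one place: nitro in place of fluoro on an aromatic carbon. For the measured compounds named here, no measured step concerns a change on the aromatic ring itself; the step from compound 1 to compound 3 exchanges cyclohexyl for 4-fluorophenyl on the saturated chain and runs toward weaker inhibition beyond the scatter. Nothing shown suggests that a nitro in place of fluoro would reverse that. Compound 4 is therefore expected to remain near the limit of this assay, with a step of a number no higher from compound 3 to compound 4 (the limit leaves the size open) expected to lie within the scatter. The estimate for compound 4 in this assay is 20000 nM, with a range from 6000 nM to 60000 nM.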

Compound 4, half-maximal inhibitory concentration: > 20000 nM
Compound 4: no number, only a limit (the forecaster's own chance of this, stated with the estimate: 60%); the middle value lies on the limit itself.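

Compound 4 gives only a limit in this assay, > 20000 nM. Cyclohexyl replaced by 4-nitrophenyl on the same chain gives an at least 10-fold higher number from compound 1 to compound 4 (1.00 log units; beyond the scatter), so the weak result of the 4-fluorophenyl ester in compound 3 is no longer a single case: both aromatic esters shown fall on the weak side of the cyclohexyl ester of compound 1, with fluoro and nitro as two different groups on the ring. The step between compound 3 and compound 4 cannot be read, so fluoro and nitro cannot be put in any order, and both compounds stand at the same limit: the limit of > 20000 nM in this assay, at which 2 of the 4 values shown sit.

On these data alone, what stays open is how far beyond the limit compound 3 and compound 4 lie, and whether the weak result belongs to the aromatic ring itself or to the groups carried on it. An unsubstituted phenyl on the same chain, an amine in place of the nitro, or a longer chain carrying the cyclohexyl would help separate these readings.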